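Fluoro Added Para: Two Matched Pairs on One Kinase

The compounds below may be only part of what the source reports. "The series", "measured", "known", "first", "only" and "open" are said of these compounds alone.

Measured so far:
compound 1, `Cn1cnc2c(Nc3ccccc3)ncnc21`, 0% in an assay on isolated protein for inhibition of RAC-alpha serine/threonine-protein kinase (Homo sapiens), tested at 30 uM; on this read-out lower numbers stand for less inhibition and higher numbers for more inhibition at the one concentration tested (going by the name of the read-out)
compound 2, `Cn1cnc2c(Nc3ccc(F)cc3)ncnc21`, 0% in this assay
compound 3, `c1ccc(Cn2cnc3c(Sc4ccccc4)ncnc32)cc1`, 1% in this assay

Compound 1 and compound 2 share a core and differ only in one change, (fluoro in place of hydrogen on an aromatic carbon). That step, no change at the digits printed from compound 1 to compound 2 (within the scatter), left the read-out essentially where it was. Compound 3 is built on a core whose difference from that of compound 1 is not broken down here; its own value sits among the other two, all three lying within the usual scatter of one another.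

Compound 4, `Fc1ccc(Sc2ncnc3c2ncn3Cc2ccccc2)cc1`, has not yet been measured. It relates to compound 3 by fluoro in place of hydrogen on an aromatic carbon, the same change that relates compound 2 to compound 1, made at the same kind of place. Since the step of no change at the digits printed from compound 1 to compound 2 (within the scatter) was flat, the expectation is that no change at the digits printed from compound 3 to compound 4 (within the scatter) will be similarly flat in this assay. Compound 4 is therefore estimated at 1%, with the spread 0% to 8% covering the usual scatter.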

Compound 4, a percentage reported as inhibition, at one concentration (the size of the read-out at that concentration, not a potency): 1%
The estimate for compound 4 equals the measured number at the digits printed; the measured number falls inside the stated range.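

Fluoro in place of hydrogen on an aromatic carbon gave no change at the digits printed from compound 3 to compound 4 (within the scatter) in this assay, and the change behaves alike on both cores: the same change on two cores in this assay, no change at the digits printed (within the scatter) from compound 1 to compound 2 and no change at the digits printed (within the scatter) from compound 3 to compound 4, 0 percentage points apart, within the scatter of two such steps

This agreement carries little weight, however, since all four compounds show almost no inhibition at the single concentration tested, so the flat steps say only that adding this fluoro did not lift either core out of that range. They do not show that the change would be equally silent on a compound with clear inhibition, and two matched pairs make no general rule for the series.

As far as these compounds go, it remains open whether any compound of this family can give clear inhibition in this assay at all. From the compounds shown here alone, it is also open whether a group other than fluoro in place of that same hydrogen, such as an amine, a carboxylic acid or a longer chain, would move the read-out on either core.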